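The source may report more compounds than this note shows. Statements on the series, on what has been measured and on what is new or still open speak of the compounds shown alone.

Working notes on a small set of sulfonyl enones. Compound 1 `Cc1ccc(S(=O)(=O)/C(=C/c2ccc(C)s2)C(=O)c2ccc(Cl)cc2)cc1` and compound 2 `Cc1ccc(/C=C(\C(=O)c2ccc(Cl)cc2)S(=O)(=O)Cc2ccc(F)cc2)s1` share one core and differ in a single place: 4-methylphenyl in place of 4-fluorobenzyl on a sulfonyl sulfur. In a functional assay on DU-145 cells (Homo sapiens) for inhibition, read by trypan blue exclusion, with a stated time of 96 h (a lower number here means a stronger inhibitor of growth, a higher number a weaker inhibitor of growth), compound 2 gives 50000 nM, and compound 1 gives 50000 nM, so the step of no change at the digits printed from compound 2 to compound 1 (within the scatter).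

Compound 3 `COc1cc(OC)c(/C=C(\C(=O)c2ccc(Cl)cc2)S(=O)(=O)Cc2ccc(F)cc2)c(OC)c1` carries a different core; how the core of compound 3 differs from the core of compound 2 is not broken down here. In this assay compound 3 gives 25000 nM. That number sits nearest to compound 1 and furthest from compound 2, yet both gaps lie within the scatter, so no order among the three compounds is claimed.

Compound 4 `COc1cc(OC)c(/C=C(\C(=O)c2ccc(Cl)cc2)S(=O)(=O)c2ccc(C)cc2)c(OC)c1` has not been measured. It stands to compound 3 exactly as compound 1 stands to compound 2: 4-methylphenyl in place of 4-fluorobenzyl on a sulfonyl sulfur. The surroundings of the place read the same word for word in both pairs, so this is the same change, made twice in the set. The step from compound 3 to compound 4 is expected to be small, essentially flat, because the same change on the other core gave no change at the digits printed from compound 2 to compound 1 (within the scatter). On that basis the expected step is no change at the digits printed from compound 3 to compound 4 (within the scatter). Compound 4 is therefore estimated to give about 25000 nM in this assay. The expected range for compound 4 runs from 12000 nM to 50000 nM. Among the compounds with values here, with only two cores and one repeated change, nothing beyond these four compounds is inferred.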

Compound 4, concentration for 50% growth inhibition: 25000 nM
For compound 4 middle estimate and measured number coincide at the digits printed, within the range that was stated.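

In this assay, 4-methylphenyl in place of 4-fluorobenzyl on a sulfonyl sulfur gives, on the core of compound 3, no change at the digits printed from compound 3 to compound 4 (within the scatter). The change therefore behaves alike on the two cores, and the two steps agree: the same change on two cores in this assay, no change at the digits printed (within the scatter) from compound 2 to compound 1 and no change at the digits printed (within the scatter) from compound 3 to compound 4, 1.0-fold (0.00 log units) apart, within the scatter of two such steps This shows that exchanging these two groups is a flat step on both cores in this one assay, but two pairs do not establish a rule for other cores or other read-outs, and they give no explanation for the flatness.

The compounds shown leave open whether any other group on the sulfonyl sulfur, such as a longer chain or a chain ending in an amine or a carboxylic acid, would produce a step beyond the scatter in this assay. It also remains open whether the two cores would still respond alike to a change that moves the number at all, since the only repeated change shown here produces no step on either core.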